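Three ether variants in hand, a fourth benzyl ether awaits

The source may report more compounds than this note shows. Statements on the series, on what has been measured and on what is new or still open speak of the compounds shown alone.

Three compounds share one core and differ only in the group on the aromatic ether oxygen. Compound 1 `CCN(CC)C(=O)Cc1c(-c2ccc(OC3CCC3)cc2)nn2c(C)cc(C)nc12` gives 0.86 nM in an assay on isolated protein (kidney, strain Wistar) for displacement of a labelled ligand from Translocator protein (Rattus norvegicus), read by scintillation counting, with a stated time of 90 min; a higher number here means a weaker inhibitor, a lower number a stronger inhibitor; compound 2 `CCN(CC)C(=O)Cc1c(-c2ccc(OC3CCCC3)cc2)nn2c(C)cc(C)nc12` gives 1.5 nM; compound 3 `CCN(CC)C(=O)Cc1c(-c2ccc(OCc3ccc(F)cc3)cc2)nn2c(C)cc(C)nc12` gives 0.77 nM. Compound 3 has the lowest of the three numbers, yet the steps of a 1.1-fold lower number from compound 1 to compound 3 (0.05 log units; within the scatter) and a 1.9-fold lower number from compound 2 to compound 3 (0.29 log units; within the scatter) both sit within the scatter, as does a 1.7-fold higher number from compound 1 to compound 2 (0.24 log units; within the scatter), so the three compounds cannot be separated by these numbers.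

Compound 4 `CCN(CC)C(=O)Cc1c(-c2ccc(OCc3ccccc3C(F)(F)F)cc2)nn2c(C)cc(C)nc12` is not yet measured. It differs from compound 3 by 2-(trifluoromethyl)phenyl in place of 4-fluorophenyl on a saturated chain carbon bound to an oxygen on an aromatic ring. All three measured steps concern the same ether position and none of them exceeds the scatter, including the move from cyclopentyl to 4-fluorobenzyl. On that basis compound 4 is expected to give 1 nM, with a range from 0.4 nM to 3 nM, an estimated step of a 1.3-fold higher number from compound 3 to compound 4 (0.11 log units; within the scatter), not beyond the scatter.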

Compound 4, inhibition constant: 1.4 nM
For compound 4 the middle estimate is 1.4-fold (0.15 log units) below the measured one; the measured number falls inside the stated range.
By their numbers in this assay, from the lowest: compounds 3, 1, 4 and 2 (each within the scatter of the next).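

In this assay the exchange of 4-fluorobenzyl for 2-(trifluoromethyl)benzyl gives a 1.8-fold higher number from compound 3 to compound 4 (0.26 log units; within the scatter) and so shows that a change on the aromatic ring of the benzyl ether, from 7 to 10 heavy atoms in the group that changes, also stays inside the scatter. Set against the two saturated ring ethers, the new group gives a 1.1-fold lower number from compound 2 to compound 4 (0.03 log units; within the scatter) and a 1.6-fold higher number from compound 1 to compound 4 (0.21 log units; within the scatter) and therefore cannot be separated from either of them, which leaves all four compounds unresolved at this position. Nothing at hand offers a reason for this flat result.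

The compounds shown leave open whether 2-fluorobenzyl or 4-(trifluoromethyl)benzyl would fall within the same scatter. They also leave open whether an amine, a carboxylic acid or a longer chain on the ether oxygen would produce a step beyond it.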